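This account rests on a few compounds, and the source may have more. Where it says the series, first, only, none or still open, it means among the compounds named here.

Measured so far:
Compound 1 `COCCNS(=O)(=O)c1ccc(C)c(C#Cc2cc(Cl)ccc2OCC(=O)O)c1`: < 10 mL.min-1.g-1 (a limit of the assay)
Compound 2 `Cc1ccc(S(=O)(=O)NC(C)C)cc1C#Cc1cc(Cl)ccc1OCC(=O)O`: 12 mL.min-1.g-1

Among the measured compounds shown here, in an in vitro ADME assay on microsomes from liver (Rattus norvegicus) for metabolic stability, read by LC-MS, tested at 1 uM (on this read-out lower numbers stand for slow clearance and higher numbers for fast clearance), compound 2 gives 12 mL.min-1.g-1, the only true number so far. Compound 1 gives < 10 mL.min-1.g-1, which is a limit of the assay and not a number. For the measured compounds named here, the one measured step is an at least 1.2-fold higher number from compound 1 to compound 2 (0.07 log units; that floor lies within the scatter). Going by the values given here, it is the sole guide on direction, and it points only weakly upward, with its true size hidden behind (the limit of < 10 mL.min-1.g-1 in this assay, at which 1 of the 2 values shown sits).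

Compound 3 `Cc1ccc(S(=O)(=O)N2CCCCC2C)cc1C#Cc1cc(Cl)ccc1OCC(=O)O` differs from compound 2 in having 2-methylpiperidin-1-yl in place of isopropylamino on a sulfonyl sulfur. This swap adds carbon atoms in a ring and removes the hydrogen-bond donor. Among the compounds with values here, no measured pair covers such a change, so the expectation stays anchored on compound 2 at 12 mL.min-1.g-1 and carries a wide range. A modest rise in this assay is expected, with an estimated size of a 2.1-fold higher number from compound 2 to compound 3 (0.32 log units; beyond the scatter). For compound 3 the estimate is 25 mL.min-1.g-1, with an expected range from 10 mL.min-1.g-1 to 60 mL.min-1.g-1.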

Compound 3, intrinsic clearance in microsomes: 418 mL.min-1.g-1
Beside the measured number, compound 3's estimate is 17-fold (1.22 log units) below it; the measured number lies above the stated range.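

Swapping isopropylamino for 2-methylpiperidin-1-yl on a sulfonyl sulfur gives a 35-fold higher number from compound 2 to compound 3 (1.54 log units; beyond the scatter) in this assay, so this position can move clearance far more than the earlier step between two open-chain groups could show. The change from the (2-methoxyethyl)amino group points the same way, with an at least 41-fold higher number from compound 1 to compound 3 (1.62 log units; beyond the scatter), and in both steps a six-membered non-aromatic ring enters and a hydrogen-bond donor leaves. Compound 1 gives < 10 mL.min-1.g-1, a limit of the assay and not a number, so that second step is only a floor: the limit of < 10 mL.min-1.g-1 in this assay, at which 1 of the 3 values shown sits.

Because ring, added carbon atoms and lost donor all change in one swap, the compounds shown leave open which of them goes with the jump in clearance. Plain piperidin-1-yl would test whether the methyl on the ring is needed, and dimethylamino would show what removing the donor does when no ring enters.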